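Cytotoxicity on Vero cells: from chloro to methoxy

A few compounds are considered here, and "the series" means these few. Any claim that something is new, unique, unknown or untested is made for them only; others in the source may bear on it.

Compound 1 `O=C1CSC(c2cccc(F)c2)N1CCN1CCCCC1`: 100%
Compound 2 `O=C1CSC(c2ccccc2Cl)N1CCN1CCCCC1`: 100%

Of the compounds shown here, two have been measured in an ADME assay on Vero cells (Chlorocebus sabaeus) for cytotoxicity, read by neutral red uptake, tested at 25 ug/mL; a higher number here means a weaker effect of the compound at the concentration tested, a lower number a stronger effect. Compound 1 `O=C1CSC(c2cccc(F)c2)N1CCN1CCCCC1` gives 100% in this assay, and compound 2 `O=C1CSC(c2ccccc2Cl)N1CCN1CCCCC1` gives 100%. For the measured compounds named here, the one measured step, no change at the digits printed from compound 1 to compound 2 (within the scatter), shows that exchanging the substituted phenyl on the saturated ring carbon left the read-out unchanged within the scatter. Compound 2 therefore stands level with compound 1 at the digits shown.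

Compound 3 `COc1ccccc1C1SCC(=O)N1CCN1CCCCC1` differs from compound 2 in one place: methoxy in place of chloro on an aromatic carbon. Going by the values given here, no measured step touches this aromatic position, so the only guide is that the one change made so far, the step from compound 1 to compound 2, moved nothing. On that basis no step beyond the scatter is expected in this assay, which means an expected step of no change at the digits printed from compound 2 to compound 3 (within the scatter). Compound 3 is thus estimated at 100%, in the range 85% to 100%.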

Compound 3, a percentage reported as activity, at one concentration (the size of the read-out at that concentration, not a potency): 100%
Beside the measured number, compound 3's estimate shows no gap at the digits printed; the measured number falls inside the stated range.
By their numbers in this assay, from the lowest: compounds 1, 2 and 3 (each within the scatter of the next).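

In this assay, the change at this aromatic carbon, ortho to a large group, gave no change at the digits printed from compound 2 to compound 3 (within the scatter). For the compounds shown here, this is the first measured step at this position, and it shows that methoxy, which carries a hydrogen-bond acceptor, can take the place of chloro, which carries none, with the read-out staying level. Nothing measured here accounts for this result.

The compounds shown leave open whether an amine, a carboxylic acid or a longer chain such as butoxy on this aromatic carbon would also leave the read-out level. As far as these compounds go, all three compounds stand level in this assay, so it also remains open which change to the shared core, if any, would move the read-out beyond the scatter.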